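The source may hold more compounds than are shown below. What is called first, only, known or untested is meant among the compounds shown, and "the series" means these compounds.

Measured so far in an assay on cells for inhibition of ileal sodium/bile acid cotransporter (Homo sapiens); on this read-out lower numbers stand for stronger inhibition and higher numbers for weaker inhibition. Compound 1 `CCCC[C@]1(CC)CS(=O)(=O)c2ccc(N)cc2[C@@H](c2ccccc2)[C@H]1O` gives 68 nM. Compound 2 `CCCC[C@]1(CC)CS(=O)(=O)c2ccc(N(O)C(=O)OC(C)(C)C)cc2[C@@H](c2ccccc2)[C@H]1O` gives 2670 nM. Compound 3 `CCCCCCNc1ccc2c(c1)[C@@H](c1ccccc1)[C@@H](O)[C@](CC)(CCCC)CS2(=O)=O` gives 1670 nM.

Compound 3 holds the second highest of the three numbers: the step of a 1.6-fold lower number from compound 2 to compound 3 (0.20 log units; within the scatter) lies within the scatter, while the step of a 25-fold higher number from compound 1 to compound 3 (1.39 log units; beyond the scatter) lies well beyond it.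

The next change on the shared core is methylsulfonyl in place of hexyl on a nitrogen on an aromatic ring, giving compound 4 `CCCC[C@]1(CC)CS(=O)(=O)c2ccc(NS(C)(=O)=O)cc2[C@@H](c2ccccc2)[C@H]1O`. For the measured compounds named here, two measured steps bear on it. Each step that puts a group onto the nitrogen on the aromatic ring of compound 1 has raised the number by a large amount: a 39-fold higher number from compound 1 to compound 2 (1.59 log units; beyond the scatter) and a 25-fold higher number from compound 1 to compound 3 (1.39 log units; beyond the scatter). Going by the values given here, the only step between two substituted nitrogens, a 1.6-fold lower number from compound 2 to compound 3 (0.20 log units; within the scatter), stays within the scatter. Among the compounds with values here, compound 4 keeps a substituted nitrogen, so its number is expected to sit closer to compounds 2 and 3 than to compound 1, though no measured step covers a methylsulfonyl there, and the range is kept wide. From compound 3, the expected step is a 3.3-fold lower number from compound 3 to compound 4 (0.52 log units; beyond the scatter). Compound 4 is therefore estimated at 500 nM, between 120 nM and 2500 nM.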

Compound 4, half-maximal inhibitory concentration: 600 nM
Compound 4: middle estimate off by 1.2-fold (0.08 log units), on the low side; the measured number falls inside the stated range.
By their numbers in this assay, from the lowest: compound 1; then compound 4; then compounds 3 and 2 (each within the scatter of the next).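

On the nitrogen on an aromatic ring, substituents now separate beyond the scatter in this assay with a 2.8-fold lower number from compound 3 to compound 4 (0.44 log units; beyond the scatter) and with a 4.5-fold lower number from compound 2 to compound 4 (0.65 log units; beyond the scatter) as the two steps that show it, whereas the earlier pair of substituted nitrogens stayed within the scatter. Substitution there still raises the number over the free amino group, but an 8.8-fold higher number from compound 1 to compound 4 (0.95 log units; beyond the scatter) in this assay is a modest step where the two earlier steps from compound 1 were large, so the size of the rise varies with the group that enters. The data shown hold no evidence on why methylsulfonyl and hexyl differ at this nitrogen.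

Open, from the compounds shown here alone, is whether a methyl or an acetyl group on the same nitrogen would come closer to compound 1. Also open, going by these compounds, is whether a longer sulfonyl chain such as butylsulfonyl would hold the level of compound 4.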